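Inversion at the chain stereocentre: compound 2 to compound 3

The source may report more compounds than this note shows. Statements on the series, on what has been measured and on what is new or still open speak of the compounds shown alone.

Two ureas have been measured in an ADME assay on the whole organism with Oryza sativa as the target, tested at 10 uM; on this read-out higher numbers stand for a weaker effect at the one concentration tested and lower numbers for a stronger effect. Compound 1, `C[C@H](NC(=O)Nc1cccc(Cl)c1)c1ccccc1`, gives 103% in this assay. Compound 2, `C[C@@H](NC(=O)Nc1cc(Cl)cc(Cl)c1)c1ccccc1`, gives 99% in this assay. The two numbers lie within the usual scatter of each other, so the gap between compound 1 and compound 2 carries no weight; both read-outs sit where a negligible effect at the single concentration would be expected.

The next compound, compound 3, `C[C@H](NC(=O)Nc1cc(Cl)cc(Cl)c1)c1ccccc1`, is the mirror counterpart of compound 2 at its single stereocentre: the two compounds have the same atoms and bonds and differ only in configuration as drawn: 1 of 1 stereo elements differ; a stereocentre at a saturated chain carbon is drawn R in compound 2 and S in compound 3.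

For the measured compounds named here, no step between two measured compounds shows how this assay responds to a change of configuration alone, and the two measured compounds agree with each other. With no basis for a direction, no step beyond the scatter is expected in this assay; the estimated movement is a number 1 percentage points higher from compound 2 to compound 3 (within the scatter), essentially none. Compound 3 is accordingly expected to give 100% in this assay, with a range from 88% to 112%, the width reflecting the scatter of repeated measurements and the absence of any comparison of configuration among the measured compounds.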

Compound 3, a percentage reported as activity, at one concentration (the size of the read-out at that concentration, not a potency): 99%
Compound 3: middle estimate off by 1 percentage points, on the high side; the range from low to high includes it.
By their numbers in this assay, from the lowest: compounds 2, 3 and 1 (each within the scatter of the next).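

In this assay, the chain stereocentre now has a direct test, and inverting it gives no change at the digits printed from compound 2 to compound 3 (within the scatter). This step isolates the stereocentre, with nothing else in the structure changing: the fact that compounds 2 and 3 differ only in the configuration as drawn. For the compounds shown here, the only other single-place step, chloro in place of hydrogen on an aromatic carbon, gives a number 4 percentage points lower from compound 1 to compound 3 (within the scatter), so neither change moves this read-out beyond the scatter, and all three compounds remain where a negligible effect at the single concentration would be expected.

A flat result in this range cannot show whether configuration would matter in a compound with a clear effect at this concentration, so the stereocentre is not established as irrelevant to the series in general. On these data alone, it also remains open whether a carboxylic acid or an amine in place of chloro on the aromatic ring, or a longer chain at the stereocentre, would shift the read-out in this assay beyond the scatter.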